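Replacing a nitrile with a styryl chain on a cyclohexane core

This account rests on a few compounds, and the source may have more. Where it says the series, first, only, none or still open, it means among the compounds named here.

Measured so far:
Compound 1 `C/N=C(/S)C1(c2cccnc2)CCCC/C1=C\COc1ccc(O)cc1` gives 300 nM in a functional assay (aorta) with Rattus norvegicus as the target; on this read-out higher numbers stand for weaker inhibition and lower numbers for stronger inhibition.
Compound 2 `C/N=C(/S)[C@@]1(c2cccnc2)CCCC[C@@H]1CC#N` gives 300 nM in this assay.

Compound 2 stands level with compound 1 in this assay, the two values lying within the usual scatter. Compound 3 `C/N=C(/S)[C@@]1(c2cccnc2)CCCC[C@@H]1C/C=C/c1ccccc1` is not yet measured; it differs from compound 2 by 2-phenylethenyl in place of cyano on a saturated chain carbon bound to a saturated ring carbon. Among the measured compounds shown here, no measured pair shows what such a change does here, and compound 1, carrying a larger group at a comparable position, matches compound 2, so the step of no change at the digits printed from compound 2 to compound 3 (within the scatter) is expected to stay within the scatter. Compound 3 is therefore estimated at 300 nM, with a range from 100 nM to 1000 nM.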

Compound 3, concentration for 90% inhibition: 100 nM
Beside the measured number, compound 3's estimate is 3.0-fold (0.48 log units) above it; measured number inside the range.
By their numbers in this assay, from the lowest: compound 3; then compounds 1 and 2 (each within the scatter of the next).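

At this saturated chain carbon bound to a saturated ring carbon, 2-phenylethenyl in place of cyano gives a 3.0-fold lower number from compound 2 to compound 3 (0.48 log units; beyond the scatter) in this assay. The position therefore accepts a larger group carrying a six-membered aromatic ring of carbon only, and the number falls beyond the scatter. Nothing measured here gives a reason for this step.

The compounds shown leave open whether the double bond matters, which a 2-phenylethyl group would test. Going by these compounds, how an amine or a carboxylic acid at the end of this chain would read also remains open.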